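Swapping trifluoromethyl for chloro on a cytotoxic series

A few compounds are considered here, and "the series" means these few. Any claim that something is new, unique, unknown or untested is made for them only; others in the source may bear on it.

- compound 1 `CN1C/C(=C\c2ccncc2)C(=O)/C(=C/c2ccccc2C(F)(F)F)C1`: 4100 nM
- compound 2 `O=C1/C(=C/c2cccnc2)CN(S(=O)(=O)c2ccc(Cl)cc2)C/C1=C\c1ccccc1C(F)(F)F`: 4880 nM
- compound 3 `O=C1/C(=C/c2ccncc2)CN(S(=O)(=O)c2ccc(C(F)(F)F)cc2)C/C1=C\c1ccccc1C(F)(F)F`: 3840 nM

In a functional assay on SMMC-7721 cells (Homo sapiens) for cytotoxicity, read by MTT assay, with a stated time of 24 h (a higher number here means a weaker inhibitor, a lower number a stronger inhibitor), compound 3 gives 3840 nM, which lies within the usual scatter of both compound 1 and compound 2, so these values cannot be ranked. Compound 4 `O=C1/C(=C/c2ccncc2)CN(S(=O)(=O)c2ccc(Cl)cc2)C/C1=C\c1ccccc1C(F)(F)F` differs from compound 3 in one place: chloro in place of trifluoromethyl on an aromatic carbon, para to a large group (chloro in place of trifluoromethyl on an aromatic carbon). For the measured compounds named here, no measured pair differs in only one place, so there is no direct precedent. Compound 2 also carries 4-chlorophenyl and gives 4880 nM, so no step beyond the scatter is expected in this assay. The expected change is a 1.1-fold higher number from compound 3 to compound 4 (0.05 log units; within the scatter). For compound 4 the estimated value is 4300 nM, with an expected range of 2400 nM to 7500 nM.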

Compound 4, half-maximal inhibitory concentration: 5510 nM
Estimate against measurement, compound 4: 1.3-fold (0.11 log units) below; low and high end bracket the measured number.
By their numbers in this assay, from the lowest: compounds 3, 1, 2 and 4 (each within the scatter of the next).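

In this assay the swap to chloro on this aromatic carbon, para to a large group, gives a 1.4-fold higher number from compound 3 to compound 4 (0.16 log units; within the scatter), so this first direct test cannot tell chloro from trifluoromethyl here. The other single changes read the same way: pyridin-4-yl for pyridin-3-yl gives a 1.1-fold higher number from compound 2 to compound 4 (0.05 log units; within the scatter), and (4-chlorophenyl)sulfonyl for methyl on the ring nitrogen gives a 1.3-fold higher number from compound 1 to compound 4 (0.13 log units; within the scatter), so none of these three changes separates its pair. No independent measurement here bears on why these values sit so close.

On these data alone, whether an amine or a carboxylic acid on that same carbon would shift the number beyond the scatter stays open.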